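Eighth-position exchanges on the shared core

A few compounds are considered here, and "the series" means these few. Any claim that something is new, unique, unknown or untested is made for them only; others in the source may bear on it.

The shared core is that of compound 1 `Nc1nc(OCc2ccccc2)c2[nH]c(N)nc2n1`, which in an assay on HT-29 cells with Methylated-DNA--protein-cysteine methyltransferase (Homo sapiens) as the target, with a stated time of 4 h (on this read-out higher numbers stand for an effect only at larger amounts of compound and lower numbers for an effect already at smaller amounts), gives 2 uM; this is the highest of the two numbers recorded, the nearest being compound 2 `Nc1nc(OCc2ccccc2)c2[nH]c(Br)nc2n1` with 0.06 uM. Among the compounds with values here, the one step available, a 33-fold lower number from compound 1 to compound 2 (1.52 log units; beyond the scatter), replaces the same amino group that compound 3 loses, so it bears directly on the step in question. Compound 3 `Nc1nc(OCc2ccccc2)c2[nH]c(C(F)(F)F)nc2n1` differs from compound 1 by trifluoromethyl in place of amino on an aromatic carbon. Within the data shown here, no measured step reports a trifluoromethyl group on the core, so its own effect is unknown; the only guide is that removing the amino group at this place, as in the step to compound 2, gave a large drop in the number. A step of similar direction and of comparable though perhaps somewhat smaller size is therefore expected for compound 3, namely a 20-fold lower number from compound 1 to compound 3 (1.30 log units; beyond the scatter). For compound 3 the estimate in this assay is 0.1 uM, with a range from 0.02 uM to 0.5 uM, the upper end allowing for a weaker response than that seen with compound 2.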

Compound 3, concentration for half-maximal effect: 0.25 uM
Compound 3: middle estimate off by 2.5-fold (0.40 log units), on the low side; low and high end bracket the measured number.
By their numbers in this assay, from the lowest: compound 2; then compound 3; then compound 1.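

In this assay the step to trifluoromethyl gives an 8.0-fold lower number from compound 1 to compound 3 (0.90 log units; beyond the scatter) and so shows that the lower number at this place, on an aromatic carbon between two ring nitrogen atoms, is not confined to bromo; among the listed compounds, both replacements of amino lower the number. The two replacements are not interchangeable, since the direct comparison gives a 4.2-fold higher number from compound 2 to compound 3 (0.62 log units; beyond the scatter) and places trifluoromethyl between bromo and amino in this series. No available evidence accounts for the order of the three groups at this place.

The compounds shown leave open how other groups at this place would rank against bromo and trifluoromethyl, for example hydrogen, chloro, iodo, methyl or nitrile, and whether a methylamino or dimethylamino group would stay close to amino. Also open, as far as these compounds go, is whether the same order of the three groups would hold on a core carrying a longer alkoxy chain or a substituted benzyloxy group in place of the benzyloxy group of compound 1.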